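This account rests on a few compounds, and the source may have more. Where it says the series, first, only, none or still open, it means among the compounds named here.

Compound 2 `NC(=O)c1cc(Cl)c2c(Cl)c(C#CCN3CCCC3=O)n([C@H]3CCCNC3)c2n1` is one of the two compounds measured in a functional assay on KG-1 cells (Homo sapiens) for antiproliferative activity; on this read-out higher numbers stand for an effect only at larger amounts of compound and lower numbers for an effect already at smaller amounts; compound 2 gives 178 nM, the only number shown for it, with one further entry that carries no number. Compound 1 `NC(=O)c1cc(Cl)c2c(Cl)c(C#CC3CCCO3)n([C@H]3CCCNC3)c2n1` gives 223 nM; 91 nM (2 entries) in this assay, and these repeated entries lie within the usual scatter of one another, as the several entries of compound 1 in this assay, 223 nM; 91 nM (2 entries) shows. Compound 3 `COCCC#Cc1c(Cl)c2c(Cl)cc(C(N)=O)nc2n1[C@H]1CCCNC1` is not yet measured and differs from compound 2 in a single place (methoxymethyl in place of 2-oxopyrrolidin-1-yl on a saturated chain carbon bound to a triple-bonded carbon). For this change a step of no more than the usual scatter is expected in either direction a 1.2-fold lower number from compound 2 to compound 3 (0.07 log units; within the scatter). Compound 3 is therefore estimated at 150 nM, within a range from 50 nM to 500 nM.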

Compound 3, half-maximal effective concentration: 39 nM
The estimate for compound 3 lay 3.8-fold (0.59 log units) above the measured number; measured number outside the range, below it.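

In this assay, replacing 2-oxopyrrolidin-1-yl with methoxymethyl on a saturated chain carbon bound to a triple-bonded carbon gives a 4.6-fold lower number from compound 2 to compound 3 (0.66 log units; beyond the scatter), so the read-out does respond to the group at this place. The change removes the ring and leaves the group with fewer heavy atoms, while the count of hydrogen-bond acceptors stays the same. Nothing shown gives a cause for this step.

Still open, on these data alone, is whether the ring or the size of the group matters more. Also open, as far as these compounds go, is how an amine or a plain ethyl chain would read here.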